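A few compounds are considered here, and "the series" means these few. Any claim that something is new, unique, unknown or untested is made for them only; others in the source may bear on it.

Of the compounds shown here, three have so far been tested in a functional assay on A549 cells (Homo sapiens) for inhibition, read by sulforhodamine B assay, with a stated time of 48 h; a higher number here means a weaker inhibitor of growth, a lower number a stronger inhibitor of growth. Compound 3 `COc1ccc(-c2cc(/C=C/C(=O)c3ccc(N)cc3)[nH]n2)cc1OC` gives 2750 nM. Compound 1 `COc1cc(-c2cc(/C=C/C(=O)c3ccc(N)cc3)[nH]n2)cc(OC)c1OC` gives 2080 nM, and compound 2 `COc1ccc(C(=O)/C=C/c2cc(-c3cc(OC)c(OC)c(OC)c3)n[nH]2)cc1OC` gives 1860 nM. Compound 1 is built from compound 3 by a single change, (methoxy in place of hydrogen on an aromatic carbon), and that change brought a 1.3-fold lower number from compound 3 to compound 1 (0.12 log units; within the scatter). Compound 1 and compound 2 differ in one further place, and that step was a 1.1-fold lower number from compound 1 to compound 2 (0.05 log units; within the scatter). The difference between the core of compound 2 and the core of compound 3 is not broken down here. All three numbers lie within the scatter of one another, so none of them can be called stronger or weaker than the others.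

Compound 4 `COc1cc(C(=O)/C=C/c2cc(-c3cc(OC)c(OC)c(OC)c3)n[nH]2)cc(OC)c1OC` has not yet been measured. For the measured compounds named here, it is made from compound 2 by methoxy in place of hydrogen on an aromatic carbon, which is the same change, in the same surroundings, as the one that took compound 3 to compound 1. The step from compound 2 to compound 4 in this assay is expected to be a 1.2-fold lower number from compound 2 to compound 4 (0.09 log units; within the scatter), because compound 2 stands at 1860 nM and the earlier instance of this change stayed within the scatter. Compound 4 is therefore estimated at 1500 nM, most likely between 700 nM and 3500 nM.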

Compound 4, concentration for 50% growth inhibition: 2720 nM
The estimate for compound 4 lay 1.8-fold (0.26 log units) below the measured number, within the range that was stated.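

Methoxy in place of hydrogen on an aromatic carbon brought a 1.5-fold higher number from compound 2 to compound 4 (0.17 log units; within the scatter) in this assay. The two instances of this change run in opposite directions on paper, yet neither step stands out from the scatter, and neither does the gap between them: the same change on two cores in this assay, a 1.3-fold lower number (0.12 log units; within the scatter) from compound 3 to compound 1 and a 1.5-fold higher number (0.17 log units; within the scatter) from compound 2 to compound 4, 1.9-fold (0.29 log units) apart, within the scatter of two such steps. For the compounds shown here, this shows that on these two cores the change left the number essentially where it was, so a small step is all that can be carried from one core to the other; it does not show that the two cores respond alike in every case, or that the change would stay this small on a third core, since only two pairs are available.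

The compounds shown leave open whether a different group on that aromatic carbon, such as a hydroxyl, a chlorine atom or a longer chain like ethoxy, would move the number beyond the scatter. They also leave open whether the same small step would appear in cells other than those of this assay.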